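This account rests on a few compounds, and the source may have more. Where it says the series, first, only, none or still open, it means among the compounds named here.

Compound 1 `C=CC(=O)Nc1cccc(-c2nc3ccccc3s2)c1`: in a physicochemical assay for solubility, in phosphate buffer, measured as kinetic solubility, with a stated time of 18 h, at pH 7.4 (a lower number here means a less soluble compound, a higher number a more soluble compound), compound 1 gives 180 nM.
Compound 2 `O=C(CCl)Nc1cccc(-c2nc3ccccc3s2)c1`: in this assay compound 2 gives 1000 nM.

Among the compounds with values here, compound 2 stands highest of the two numbers in this assay; its only neighbour is compound 1, and the step of a 5.6-fold higher number from compound 1 to compound 2 (0.74 log units; beyond the scatter) sets the two apart. Compound 3 `O=C(Nc1cccc(-c2nc3ccccc3s2)c1)c1ccc(Cl)nc1Cl` has not yet been measured. It differs from compound 2 in one place: 2,6-dichloropyridin-3-yl in place of chloromethyl on a carbonyl carbon. Within the data shown here, only one measured step exists, and it bears on compound 3 only loosely: it also exchanged the group on the carbonyl carbon, and its size was modest, a 5.6-fold higher number from compound 1 to compound 2 (0.74 log units; beyond the scatter). Among the measured compounds shown here, no measured step puts a six-membered aromatic ring at this place, so the direction for compound 3 rests on the nature of the change rather than on a precedent within these two compounds. The expectation is a lower number in this assay for compound 3, a step of a 5.0-fold lower number from compound 2 to compound 3 (0.70 log units; beyond the scatter) that would lie beyond the scatter. Compound 3 is therefore estimated at 200 nM, with a range from 50 nM to 800 nM.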

Compound 3, solubility: 350 nM
The estimate for compound 3 lay 1.8-fold (0.24 log units) below the measured number; the range from low to high includes it.
By their numbers in this assay, from the lowest: compounds 1 and 3 (each within the scatter of the next); then compound 2.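

At this carbonyl carbon, a six-membered aromatic ring now has a measured result: in this assay, the 2,6-dichloropyridin-3-yl group gives a 2.9-fold lower number from compound 2 to compound 3 (0.46 log units; beyond the scatter), so this exchange moves the number in the opposite direction to the earlier exchange of vinyl for chloromethyl. Set against vinyl, the same ring gives a 1.9-fold higher number from compound 1 to compound 3 (0.29 log units; within the scatter), which lies within the scatter, so among these three compounds only compound 2, with chloromethyl, stands apart from the other two, while a small open group and a ring-bearing group cannot be told apart at this place. Nothing available here gives a reason for the standing of chloromethyl or for the result with the ring.

Going by these compounds, it remains open whether a plain phenyl ring, or a pyridin-3-yl ring without its two chlorine atoms, would fall with compounds 1 and 3 or with compound 2. On these data alone, it also remains open how a longer chain ending in chlorine, or a ring carrying an amine or a carboxylic acid, would read on this carbonyl carbon.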